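The source may hold more compounds than are shown below. What is called first, only, known or untested is meant among the compounds shown, and "the series" means these compounds.

Measured compounds:
- compound 1, `COc1cccc(/C=C/C(=O)Nc2cc(C(=O)c3cc(OC)c(OC)c(OC)c3)ccc2OC)c1`: 6200 nM
- compound 2, `COc1ccc(C(=O)c2cc(OC)c(OC)c(OC)c2)cc1NC(=O)/C=C/c1cccc(OC(F)(F)F)c1`: 10200 nM
- compound 3, `COc1ccc(C(=O)c2cc(OC)c(OC)c(OC)c2)cc1NC(=O)/C=C/c1ccc(N)cc1`: 13500 nM

All three were tested in a functional assay on DU-145 cells (Homo sapiens) for cytotoxicity, read by MTT assay, with a stated time of 72 h; on this read-out lower numbers stand for stronger inhibition and higher numbers for weaker inhibition. Compound 1 gives the lowest of the three numbers: the step of a 1.6-fold higher number from compound 1 to compound 2 (0.22 log units; within the scatter) stays within the scatter, while the step of a 2.2-fold higher number from compound 1 to compound 3 (0.34 log units; beyond the scatter) is a modest one beyond it. The step of a 1.3-fold higher number from compound 2 to compound 3 (0.12 log units; within the scatter) is within the scatter.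

Compound 4, `COc1cccc(/C=C/C(=O)Nc2cc(C(=O)c3cc(OC)c(OC)c(OC)c3)cc(OC)c2OC)c1`, has not yet been measured. It differs from compound 1 in one place: methoxy in place of hydrogen on an aromatic carbon. This addition sits on the shared core, on the ring that carries the amide nitrogen, ortho to a methoxy group and meta to two large groups.

Within the data shown here, none of the measured steps touches this ring; all three exchange the aryl group at the far end of the double-bonded chain, and none of them moved the number far. Among the measured compounds shown here, there is therefore no measured precedent for this change, and the expectation for compound 4 is a step of no clear size beyond the scatter, a 1.1-fold higher number from compound 1 to compound 4 (0.05 log units; within the scatter). The estimate for compound 4 in this assay is 7000 nM, ranging from 2500 nM to 20000 nM.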

Compound 4, half-maximal inhibitory concentration: 12500 nM
Compound 4: the middle estimate sits 1.8-fold (0.25 log units) below what was measured; measured number inside the range.
By their numbers in this assay, from the lowest: compounds 1, 2, 4 and 3 (each within the scatter of the next, the first and the last beyond it).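

Among these compounds, this is the first measured change on the shared core rather than on the aryl group at the far end of the chain. In this assay, placing a methoxy ortho to a methoxy group and meta to two large groups gives a 2.0-fold higher number from compound 1 to compound 4 (0.30 log units; within the scatter), so this added group of 2 heavy atoms leaves the number within the scatter and the position can carry it, at least with the 3-methoxyphenyl end of compound 1. No measurement bears on what lies behind this result.

Going by these compounds, whether this carbon would accept a different group, such as a hydroxyl, a fluorine or an amine, remains open. So does whether the same added methoxy would give a similar step alongside the 4-aminophenyl end of compound 3.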